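A few compounds are considered here, and "the series" means these few. Any claim that something is new, unique, unknown or untested is made for them only; others in the source may bear on it.

Compound 1, `O=C(Nc1ccc(-n2cc(-c3ccncc3)c(-c3ccc(Cl)c(O)c3)n2)cc1)c1ccc(Cl)c(Cl)c1`, gives 6700 nM in a functional assay on A375P cells (Homo sapiens) for antiproliferative activity, read by MTT assay, with a stated time of 48 h; a lower number here means a stronger inhibitor, a higher number a weaker inhibitor.
Compound 2, `O=C(Nc1ccc(-n2cc(-c3ccncc3)c(-c3ccc(Cl)c(O)c3)n2)cc1)c1cc(Cl)cc(Cl)c1`, gives 6800 nM in this assay.

Compound 2 holds the larger of the two numbers, yet the gap a 1.0-fold higher number from compound 1 to compound 2 (0.01 log units; within the scatter) lies within the scatter, so the two compounds are indistinguishable on these data. Compound 3, `O=C(Nc1ccc(-n2cc(-c3ccncc3)c(-c3ccc(Cl)c(O)c3)n2)cc1)c1ccc(Cl)c(C(F)(F)F)c1`, differs from compound 2 by 4-chloro-3-(trifluoromethyl)phenyl in place of 3,5-dichlorophenyl on a carbonyl carbon. Going by the values given here, the single measured step bears only loosely on this change: it swapped one dichlorophenyl for another with no shift beyond the scatter, and a trifluoromethyl now enters. No shift beyond the scatter is therefore expected, and compound 3 is estimated at 6800 nM (range 3000 nM to 15000 nM), an expected step of no change at the digits printed from compound 2 to compound 3 (within the scatter) in this assay.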

Compound 3, half-maximal inhibitory concentration: 6800 nM
Compound 3: the middle estimate sits on the measured number at the digits printed; low and high end bracket the measured number.
By their numbers in this assay, from the lowest: compounds 1, 2 and 3 (each within the scatter of the next).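

In this assay, 4-chloro-3-(trifluoromethyl)phenyl in place of 3,5-dichlorophenyl on a carbonyl carbon gives no change at the digits printed from compound 2 to compound 3 (within the scatter), so this position accepts a trifluoromethyl with no shift beyond the scatter. Trifluoromethyl in place of chloro on an aromatic carbon likewise gives a 1.0-fold higher number from compound 1 to compound 3 (0.01 log units; within the scatter) as the result. No available evidence accounts for this flat outcome.

On these data alone, whether any change at this position moves the number beyond the scatter remains open. So does the effect of an amine or a carboxylic acid on this phenyl ring.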